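The source may hold more compounds than are shown below. What is called first, only, known or untested is meant among the compounds shown, and "the series" means these compounds.

Measured so far in this set:
- compound 1 `CC1CCN(C2CCN(S(=O)(=O)c3cn(C)cn3)CC2)CC1` — > 5000 nM
- compound 2 `COC(=O)c1ccc(S(=O)(=O)N2CCC(N3CCC(C)CC3)CC2)cc1` — > 5000 nM
- compound 3 `Cc1cc(C)c(S(=O)(=O)N2CCC(N3CCC(C(C)C)CC3)CC2)c(C)c1` — 0.3 nM

In a functional assay on DLD-1 cells (Homo sapiens) for antiproliferative activity, read by CellTiter-Glo, with a stated time of 72 h (a higher number here means a weaker inhibitor, a lower number a stronger inhibitor), compound 1 gives > 5000 nM, and this is a limit of the assay rather than a measured number. Compound 2 likewise gives > 5000 nM, again a limit. Compound 3 gives 0.3 nM. Compound 1 therefore stands at the weak end of what has been measured, sharing the limit with one other compound (the limit of > 5000 nM in this assay, at which 2 of the 3 values shown sit). Among the compounds with values here, no two measured compounds differ in just one place, so no single measured step exists to guide an expectation.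

Compound 4 `CC1CCN(C2CCN(S(=O)(=O)c3cncc(Br)c3)CC2)CC1` has not yet been measured in this assay. It differs from compound 1 in one place: 5-bromopyridin-3-yl in place of 1-methyl-1H-imidazol-4-yl on a sulfonyl sulfur. The expected step is an at least 2.0-fold lower number from compound 1 to compound 4 (0.30 log units; that floor lies within the scatter), toward somewhat stronger inhibition, though only just beyond the usual scatter, and there is a real chance that the result is again a limit. Compound 4 is expected to give about 2500 nM, within a range from 300 nM to 8000 nM.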

Compound 4, half-maximal inhibitory concentration: > 5000 nM
Compound 4: no number, only a limit (the forecaster's own chance of this, stated with the estimate: 40%); middle value at least 2.0-fold (0.30 log units) away from the limit.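

Within the data shown here, compound 1 and compound 4 both stand at a limit of the assay rather than at a number, so no step between them can be read: the limit of > 5000 nM in this assay, at which 3 of the 4 values shown sit. Still open, as far as these compounds go, is whether 5-bromopyridin-3-yl and 1-methyl-1H-imidazol-4-yl differ at all in antiproliferative activity, and by how much.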